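The compounds below may be only part of what the source reports. "The series", "measured", "known", "first", "only" and "open" are said of these compounds alone.

Values in a functional assay (aorta) for inhibition, with Rattus norvegicus as the target; on this read-out lower numbers stand for stronger inhibition and higher numbers for weaker inhibition:
- compound 1 `C/N=C(/S)[C@]1(c2cccnc2)CCCC[S@@+]1[O-]`: 700 nM; 400 nM; > 30000 nM (3 entries)
- compound 2 `CC/N=C(\S)[C@]1(c2cccnc2)CCCC[S+]1[O-]`: 300 nM

One of the entries of compound 1 is a limit of the assay and not a number: the several entries of compound 1 in this assay, 700 nM; 400 nM; > 30000 nM (3 entries). Compound 2 has a single number in this assay, 300 nM, and one further entry that gives no single number, so its position rests on thin evidence.

The next compound to be read is compound 3 `O=C(O)CC/N=C(\S)[C@]1(c2cccnc2)CCCC[S+]1[O-]`, not yet measured. Relative to compound 2 it carries carboxy in place of hydrogen on a saturated chain carbon, two bonds along the chain from a double-bonded nitrogen, which turns the ethyl into 2-carboxyethyl while the core of compound 1 stays in place. Within the data shown here, no measured step shows what such a change does, so the size of the shift is a judgement and not a reading. Weaker inhibition is expected, beyond the usual scatter, and the estimated change is a 10-fold higher number from compound 2 to compound 3 (1.00 log units; beyond the scatter). The wide spread in the several entries of compound 1 in this assay, 700 nM; 400 nM; > 30000 nM (3 entries) also argues for a broad range, and a limit instead of a number would not be a surprise. For compound 3 the expected value is 3000 nM, with an estimated range of 400 nM to 25000 nM.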

Compound 3, concentration for 90% inhibition: > 30000 nM
Compound 3 gave a limit, no number; the forecaster's own chance of this, stated with the estimate: 25%; at least 10-fold (1.00 log units) between middle value and limit.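

In this assay compound 3 gives > 30000 nM, which is a limit of the assay and not a number. Carboxy in place of hydrogen on a saturated chain carbon, two bonds along the chain from a double-bonded nitrogen, gives an at least 100-fold higher number from compound 2 to compound 3 (2.00 log units; beyond the scatter), the first reading at this position, and the change to 2-carboxyethyl is therefore a large loss of inhibition on this read-out, whose full size stays unknown. Compound 1 also has a limit among its entries, alongside two numbers, so one limit on the shared core calls for caution when it stands alone: the several entries of compound 1 in this assay, 700 nM; 400 nM; > 30000 nM (3 entries)

The compounds shown do not separate the carboxy group itself from the added length of the chain that carries it, and a plain propyl chain, an amine at the chain end or a methyl ester of the carboxylic acid would each speak to that question. Among these compounds, how far the position allows any change beyond ethyl also stays open, as compound 2 at 300 nM is the only number for a chain of this kind and has one further entry without a single number.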